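A few compounds are considered here, and "the series" means these few. Any claim that something is new, unique, unknown or untested is made for them only; others in the source may bear on it.

Compound 3 `C=CCSc1nc(N)nc2c1ncn2[C@H]1C[C@H](O)[C@@H](CO)O1` holds the lowest number of the two compounds that gave a number in a functional assay on L1210 cells (Mus musculus) for inhibition, read by thymidine incorporation; a higher number here means that more compound is needed for the effect, a lower number that less compound is needed; there compound 3 gives 5.5 uM. The nearest measured compound is compound 1 `CSc1nc(N)nc2c1ncn2[C@H]1C[C@H](O)[C@@H](CO)O1`, which in this assay gives 27 uM; the step between them is a 4.9-fold lower number from compound 1 to compound 3 (0.69 log units; beyond the scatter). Compound 2 `C=CCSc1nc(N)nc2c1ncn2[C@@H]1C[C@H](O)[C@@H](CO)O1` has the same atoms and bonds as compound 3 and differs only in how one stereocentre is drawn. For compound 2 this assay reports only a limit, > 100 uM, so no number is known for it. The step of an at least 18-fold lower number from compound 2 to compound 3 (1.25 log units; beyond the scatter) therefore rests on the limit of > 100 uM in this assay, at which 1 of the 3 values shown sits, and on (the fact that compounds 2 and 3 differ only in the configuration as drawn).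

Compound 4 `Cc1cccc(CSc2nc(N)nc3c2ncn3[C@H]2C[C@H](O)[C@@H](CO)O2)n1` is compound 3 altered at a single place: 6-methylpyridin-2-yl in place of vinyl on a saturated chain carbon bound to a sulfur. Of the measured steps, only a 4.9-fold lower number from compound 1 to compound 3 (0.69 log units; beyond the scatter) touches this place, and it shows that adding vinyl to the sulfur-bound carbon lowered the number by a modest amount. Whether a further growth of that group into an aromatic ring continues in the same direction is not shown by any measured pair, so the expectation is for a step near the scatter, leaning slightly lower. The estimated step is a 1.4-fold lower number from compound 3 to compound 4 (0.14 log units; within the scatter). Compound 4 is thus expected to give 4 uM in this assay, within a range from 1 uM to 20 uM.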

Compound 4, concentration for half-maximal effect: 64 uM
Compound 4: the middle estimate sits 16-fold (1.20 log units) below what was measured; measured number above the stated range.
By their numbers in this assay, from the lowest: compound 3; then compound 1; then compound 4. At a limit, above all of these: compound 2.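

In this assay the step of a 12-fold higher number from compound 3 to compound 4 (1.07 log units; beyond the scatter) shows that the gain seen with vinyl on the saturated chain carbon bound to a sulfur does not carry over to 6-methylpyridin-2-yl. The step of a 2.4-fold higher number from compound 1 to compound 4 (0.37 log units; beyond the scatter) goes further, since the number ends up higher even than with hydrogen at this place. The earlier compounds shown here held a single change here, and it pointed downward; now the direction is seen to depend on the group, with compound 3 going against any simple rule that a larger group raises the number.

Nothing measured here speaks to why the number rose, since neither the difference in configuration nor the limit shown for compound 2 concerns this step. Still open, on these data alone, is whether the aromatic ring, its nitrogen or its methyl accounts for the rise, and how a plain phenyl group, a pyridin-2-yl group without the methyl or a longer chain such as butyl would read at this place.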